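Amide Variation on the Shared Core: Thiazole Replaces Pyridine

A few compounds are considered here, and "the series" means these few. Any claim that something is new, unique, unknown or untested is made for them only; others in the source may bear on it.

Measured compounds:
- compound 1, `O=C(Nc1ccc(Cl)c(-c2nnc3c(Cl)cccn23)c1)c1ccc(C(F)(F)F)cc1Cl`: > 100000 nM
- compound 2, `O=C(Nc1ccc(Cl)c(-c2nnc3c(Cl)cccn23)c1)c1ccc(F)cc1Cl`: > 100000 nM
- compound 3, `O=C(Nc1ccc(Cl)c(-c2nnc3c(Cl)cccn23)c1)c1ccccn1`: 79000 nM

In a functional assay on U-251 cells (Homo sapiens) for antiproliferative activity, read by MTT assay, with a stated time of 72 h (on this read-out higher numbers stand for weaker inhibition and lower numbers for stronger inhibition), compound 1 gives > 100000 nM, which is a limit of the assay and not a number. In this assay compound 2 gives > 100000 nM, again a limit. In this assay, within the data shown here, compound 3 gives 79000 nM, the only number in the set. Compounds 1 and 2 sit at the limit of > 100000 nM in this assay, at which 2 of the 3 values shown sit. The step that the two limits leave unreadable from compound 1 to compound 2 cannot be read, as both ends are limits. The step of an at least 1.2-fold lower number from compound 2 to compound 3 (0.10 log units; that floor lies within the scatter) is a floor that lies within the scatter, so compound 3 cannot be called the most potent.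

Compound 4, `Cc1nc(C(=O)Nc2ccc(Cl)c(-c3nnc4c(Cl)cccn34)c2)cs1`, differs from compound 3 by 2-methyl-1,3-thiazol-4-yl in place of pyridin-2-yl on a carbonyl carbon. Among the measured compounds shown here, no measured step covers this exchange of one heteroaryl amide for another. Given the one number and two limits, compound 4 is expected to land near compound 3, with the step of a 1.0-fold higher number from compound 3 to compound 4 (0.01 log units; within the scatter) estimated as no more than scatter. The estimate for compound 4 in this assay is 80000 nM, within 25000 nM to 150000 nM, with a fair chance that only a limit is returned.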

Compound 4, half-maximal inhibitory concentration: 74300 nM
The estimate for compound 4 lay 1.1-fold (0.03 log units) above the measured number, within the range that was stated.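

At the carbonyl carbon of the amide, one heteroaryl group takes the place of another with no readable change in this assay: 2-methyl-1,3-thiazol-4-yl for pyridin-2-yl gives a 1.1-fold lower number from compound 3 to compound 4 (0.03 log units; within the scatter). A five-membered aromatic ring holding sulfur thus reads the same here as the six-membered pyridine ring. Replacing 2-chloro-4-fluorophenyl with the thiazole gives an at least 1.3-fold lower number from compound 2 to compound 4 (0.12 log units; that floor lies within the scatter), so a second heteroaryl amide still sets up no order against the aryl amides, whose values are limits of the assay and not numbers: the limit of > 100000 nM in this assay, at which 2 of the 4 values shown sit.

Going by these compounds, whether heteroaryl amides truly separate from aryl amides remains open, as does whether any group on this carbonyl carbon can give a much lower number. A saturated ring amine such as piperidin-4-yl, or a carboxylic acid on the thiazole ring, would test this.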